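A Methyl Added to Compound 2: Expected Cell Tolerance

The source may report more compounds than this note shows. Statements on the series, on what has been measured and on what is new or still open speak of the compounds shown alone.

Measured compounds:
Compound 1, `CC1(C)C=Cc2c(ccc(C(=O)/C=C/c3cnc4ccccc4c3)c2O)O1`: in an ADME assay on Vero cells (Chlorocebus sabaeus) for cytotoxicity, read by MTT assay, with a stated time of 72 h (a higher number here means that more compound is tolerated, a lower number that less compound is tolerated), compound 1 gives "not determined" (no result reported), that is, no result was reported.
Compound 2, `CC1(C)C=Cc2c(ccc(C(=O)/C=C/c3cc4ccccc4nc3Cl)c2O)O1`: in this assay compound 2 gives 257000 nM.

Among the compounds with values here, compound 2 holds the only number in this assay; compound 1 shares the same core but was left without a result, so there is nothing to compare compound 2 against within the measured set, and nothing to say about its rank.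

Compound 3, `Cc1ccc2nc(Cl)c(/C=C/C(=O)c3ccc4c(c3O)C=CC(C)(C)O4)cc2c1`, has not yet been measured. It differs from compound 2 in one place: methyl in place of hydrogen on an aromatic carbon. A methyl replaces a hydrogen on an aromatic carbon of a six-membered aromatic ring of carbon only, part of a fused system of two rings.

Within the data shown here, with no step between measured compounds available, the expectation rests on the small size of the change, a single carbon with no ring, no donors and no acceptors. The step of a 1.1-fold lower number from compound 2 to compound 3 (0.05 log units; within the scatter) is expected to stay within the scatter, with no clear direction. Compound 3 is therefore expected to give 230000 nM, with a range from 100000 nM to 500000 nM.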

Compound 3, half-maximal cytotoxic concentration: 399000 nM
The estimate for compound 3 lay 1.7-fold (0.24 log units) below the measured number; the measured number falls inside the stated range.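

In this assay, within the data shown here, the methyl change gives the first comparison between two measured compounds, a 1.6-fold higher number from compound 2 to compound 3 (0.19 log units; within the scatter), so the two compounds cannot be told apart in how well the cells tolerate them. The result shows that, at this aromatic carbon, on a six-membered ring of carbon only within a fused system of two rings, one methyl in place of hydrogen leaves no clear mark on the read-out. This is one pair at one position, so it supports no general rule about methyl groups on this core, and no measurement given here offers an explanation for the small difference between the two numbers.

On these data alone, whether a larger or very different group at this same carbon, such as an amine, a carboxylic acid or a longer chain, would also stay within the scatter remains open. Also open, as far as these compounds go, is whether a methyl on another carbon of the same ring would leave the read-out just as unaffected in this assay.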